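The compounds below may be only part of what the source reports. "The series", "measured", "known", "first", "only" and "open" are said of these compounds alone.

In a functional assay on Jurkat cells (Homo sapiens) for inhibition, read by CCK-8 assay, with a stated time of 48 h (a lower number here means a stronger inhibitor of growth, a higher number a weaker inhibitor of growth), compound 1 (`CN1CCN(c2ccc(Nc3ncc(Cl)c(NCc4ccccc4)n3)nc2)CC1`) gives > 100000 nM as a limit. Compound 2 (`CN1CCN(c2ccc(Nc3ncc(Cl)c(NCc4ccco4)n3)nc2)CC1`) gives > 100000 nM as a limit too, not a number. Among the compounds with values here, the series so far shows only the limit of > 100000 nM in this assay, at which 2 of the 2 values shown sit, and nothing more. Within the data shown here, the sole measured step is a step that the two limits leave unreadable from compound 1 to compound 2 and offers no size to carry forward. Compound 3 (`CC(C)c1cccc(Nc2nc(Nc3ccc(N4CCN(C)CC4)cn3)ncc2Cl)c1`) carries 3-isopropylphenyl in place of (furan-2-yl)methyl on a nitrogen on an aromatic ring. The expected move, an at least 12-fold lower number from compound 2 to compound 3 (1.09 log units; beyond the scatter) toward stronger growth inhibition, is a loose estimate with no measured size behind it. Compound 3 is estimated at 8000 nM with a range from 800 nM to 80000 nM expected.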

Compound 3, concentration for 50% growth inhibition: 12300 nM
Compound 3: the middle estimate sits 1.5-fold (0.19 log units) below what was measured, within the range that was stated.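

Within the data shown here, on the nitrogen on an aromatic ring, 3-isopropylphenyl gives the only number rather than a limit so far in this assay, with an at least 8.1-fold lower number from compound 2 to compound 3 (0.91 log units; beyond the scatter). Set against benzyl at the same place, the change gives an at least 8.1-fold lower number from compound 1 to compound 3 (0.91 log units; beyond the scatter). Both sizes are lower bounds, as each starts from a limit and not from a number: the limit of > 100000 nM in this assay, at which 2 of the 3 values shown sit.

Going by these compounds, whether the step belongs to the isopropyl group or to the loss of the chain carbon stays open. An unsubstituted phenyl or a 3-methoxyphenyl on that nitrogen would separate the two.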